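From Isopropylpiperazine to Pyrrolidine: a Step Without Precedent

The compounds below may be only part of what the source reports. "The series", "measured", "known", "first", "only" and "open" are said of these compounds alone.

Of the compounds shown here, three built on one shared core have been tested in a functional assay on SK-BR-3 cells (Homo sapiens) for antiproliferative activity, read by MTT assay, with a stated time of 72 h; a higher number here means a weaker inhibitor, a lower number a stronger inhibitor. Compound 1 `CCc1ccccc1C(=O)Nc1ccc2nc(N3CCN(CC)CC3)cc(C)c2c1` gives 23900 nM. For the measured compounds named here, compound 3 `CCN1CCN(c2cc(C)c3cc(NC(=O)c4ccccc4OC)ccc3n2)CC1` gives 15700 nM, and the only measured change between neighbours, a 1.5-fold lower number from compound 1 to compound 3 (0.18 log units; within the scatter), concerns the group on the amide-bearing ring. Compound 2 `Cc1cc(N2CCN(C(C)C)CC2)nc2ccc(NC(=O)c3ccc(Cl)c(Cl)c3)cc12` gives 6680 nM, the lowest of the three numbers, standing beyond the scatter from both compound 3 and compound 1.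

Compound 4 `Cc1cc(N2CCCC2)nc2ccc(NC(=O)c3ccc(Cl)c(Cl)c3)cc12` has not yet been measured. The change from compound 2 is pyrrolidin-1-yl in place of 4-isopropylpiperazin-1-yl on an aromatic carbon. Going by the values given here, no measured step touches this amine ring: the one step on record alters a different part of the molecule, and compounds 1 and 3 differ from compound 2 in the amide-side group as well, so their numbers give no guide to this swap. Without a precedent, the expected direction is uncertain, and a wide range is appropriate. Compound 4 is therefore estimated to give 15000 nM, within 4000 nM to 60000 nM. The expected step is a 2.2-fold higher number from compound 2 to compound 4 (0.35 log units; beyond the scatter).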

Compound 4, half-maximal inhibitory concentration: 43400 nM
Estimate against measurement, compound 4: 2.9-fold (0.46 log units) below, and the stated range covers the measured number.
By their numbers in this assay, from the lowest: compound 2; then compounds 3, 1 and 4 (each within the scatter of the next, the first and the last beyond it).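

For the compounds shown here, this is the first measured change at this amine position on the shared core, and in this assay the position proves sensitive: a 6.5-fold higher number from compound 2 to compound 4 (0.81 log units; beyond the scatter) is what the swap does when the rest of compound 2 stays the same. The change is not a single one, as the six-membered ring with two hetero atoms and its isopropyl group leave together, and a five-membered ring with one hetero atom enters. Nothing shown here gives a measured reason for the rise in the number.

As far as these compounds go, it remains open which part of the swap matters, and piperidin-1-yl or 4-methylpiperazin-1-yl on the otherwise unchanged compound 2 would help separate them. From the compounds shown here alone, whether the step holds with the amide-side groups of compound 1 or compound 3 is also open.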